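Compound 3 to compound 4: a tolerance estimate

The compounds below may be only part of what the source reports. "The series", "measured", "known", "first", "only" and "open" are said of these compounds alone.

Of the compounds shown here, three built on a shared core have been tested in an ADME assay on HEK-293T cells (Homo sapiens) for cytotoxicity, read by MTT assay, with a stated time of 3 days; a higher number here means that more compound is tolerated, a lower number that less compound is tolerated. Compound 1 `CC(C)(NC(=O)COC(=O)c1ccc([N+](=O)[O-])o1)c1ccccc1` gives > 100000 nM, which is a limit of the assay and not a number. Compound 2 `O=C(COC(=O)c1ccc([N+](=O)[O-])o1)NCC1CCCO1` gives > 100000 nM, again only a limit. Going by the values given here, compound 3 `CC(C)(C)N(Cc1cccc([N+](=O)[O-])c1)C(=O)COC(=O)c1ccc([N+](=O)[O-])o1` is the only one with an actual number, at 78000 nM. The data therefore rest largely on (the limit of > 100000 nM in this assay, at which 2 of the 3 values shown sit).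

Compound 4 `CC(C)(C)N(Cc1ccccc1C(F)(F)F)C(=O)COC(=O)c1ccc([N+](=O)[O-])o1` carries 2-(trifluoromethyl)phenyl in place of 3-nitrophenyl on a saturated chain carbon bound to an amide-type nitrogen. Among the compounds with values here, no measured pair shows what such an exchange does in this assay, so no step beyond the scatter is expected, and neither direction is favoured. The expectation is anchored on compound 3 at 78000 nM. The expected step is a 1.1-fold lower number from compound 3 to compound 4 (0.05 log units; within the scatter), which would stay within the usual scatter. The estimated value for compound 4 is 70000 nM, with an expected range of 30000 nM to 100000 nM.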

Compound 4, half-maximal cytotoxic concentration: 65000 nM
For compound 4 the middle estimate is 1.1-fold (0.03 log units) above the measured one, within the range that was stated.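

In this assay, 2-(trifluoromethyl)phenyl in place of 3-nitrophenyl on a saturated chain carbon bound to an amide-type nitrogen gives a 1.2-fold lower number from compound 3 to compound 4 (0.08 log units; within the scatter). Going by these compounds alone, this is the first measured pair in the set, and it shows that a group with hydrogen-bond acceptors and one with none cannot be told apart at this position in this assay, although the two rings carry different substituents. The pair also rests on two actual numbers, which the rest of the set does not offer: the limit of > 100000 nM in this assay, at which 2 of the 4 values shown sit.

The compounds shown leave open whether an amine or a carboxylic acid on this ring would move the number beyond the scatter. Steps to compound 1 and compound 2 cannot be read, as those compounds differ from the others in more than one place.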